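The source may hold more compounds than are shown below. What is called first, only, known or untested is meant among the compounds shown, and "the series" means these compounds.

Compounds measured in an assay on isolated protein for inhibition of acid ceramidase (Homo sapiens), read by LC-MS, with a stated time of 1 h; on this read-out higher numbers stand for weaker inhibition and lower numbers for stronger inhibition:

- compound 1 `O=C(NCCCCc1ccccc1)n1cc(-c2ccc(Cl)cc2)oc1=O` gives 83 nM
- compound 2 `O=C(NCCCCc1ccccc1)n1cc(-c2ccc(F)cc2)oc1=O` gives 185 nM
- compound 3 `COc1ccc(-c2cn(C(=O)NCCCCc3ccccc3)c(=O)o2)cc1` gives 400 nM

Compound 3 stands highest of the three numbers. The steps that lead to it are a 4.8-fold higher number from compound 1 to compound 3 (0.68 log units; beyond the scatter) and a 2.2-fold higher number from compound 2 to compound 3 (0.33 log units; beyond the scatter), both beyond the scatter, and the third measured step is a 2.2-fold higher number from compound 1 to compound 2 (0.35 log units; beyond the scatter). All three steps concern the exchange of one group for another on the same aromatic carbon of the phenyl ring.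

Compound 4 `COc1cccc(-c2cn(C(=O)NCCCCc3ccccc3)c(=O)o2)c1` differs from compound 3 in one place: 3-methoxyphenyl in place of 4-methoxyphenyl on an aromatic carbon. For the measured compounds named here, no measured step bears on this change, since none of the three moves a group around the phenyl ring rather than swapping it. The expectation therefore rests on compound 3 alone, with no direction read from the steps at hand. Compound 4 is expected to give about 400 nM, with a range from 150 nM to 1100 nM. This expected step of no change at the digits printed from compound 3 to compound 4 (within the scatter) is not beyond the scatter.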

Compound 4, half-maximal inhibitory concentration: 341 nM
Estimate against measurement, compound 4: 1.2-fold (0.07 log units) above; measured number inside the range.
By their numbers in this assay, from the lowest: compound 1; then compounds 2, 4 and 3 (each within the scatter of the next, the first and the last beyond it).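

Until now only the group on the aromatic carbon had been exchanged, and this step moves the methoxy group instead: in this assay, 3-methoxyphenyl in place of 4-methoxyphenyl gives a 1.2-fold lower number from compound 3 to compound 4 (0.07 log units; within the scatter) and so shows no difference that can be read. The 3-methoxyphenyl group also stays close to 4-fluorophenyl with a 1.8-fold higher number from compound 2 to compound 4 (0.27 log units; within the scatter), while 4-chlorophenyl remains apart with a 4.1-fold higher number from compound 1 to compound 4 (0.61 log units; beyond the scatter), so both placements of the methoxy group give numbers beyond the scatter from the chloro compound. Nothing measured here offers an explanation for the position of the methoxy group making so little difference.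

On these data alone, whether a chloro group moved in the same way would behave like the methoxy group remains open. So does the effect of an amine or a carboxylic acid on the phenyl ring.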